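The source may report more compounds than this note shows. Statements on the series, on what has been measured and on what is new or still open speak of the compounds shown alone.

Compound 1 `O=C(Cn1cc(COc2ccc3c(c2)CCC3)nn1)Nc1cccc(Cl)c1` and compound 2 `Cc1ccccc1NC(=O)Cn1cc(COc2ccc3c(c2)CCC3)nn1` share their core with compound 3 `COc1ccccc1-n1cc(COc2ccc3c(c2)CCC3)nn1`, but in an ADME assay on HEK293 cells (Homo sapiens) for inhibition, read by MTT assay, with a stated time of 48 h, tested at 25 uM (on this read-out higher numbers stand for more inhibition at the one concentration tested (going by the name of the read-out) and lower numbers for less inhibition), compound 1 gives "not determined" (no result reported) and compound 2 gives "not determined" (no result reported), so neither offers a number. In this assay, going by the values given here, compound 3 gives 19.8%, the only number available, with nothing measured to set it against. Compound 4 `Cc1ccc(-n2cc(COc3ccc4c(c3)CCC4)nn2)c(C)c1` differs from compound 3 in one place: 2,4-dimethylphenyl in place of 2-methoxyphenyl on an aromatic nitrogen. Among the compounds with values here, no step between two measured compounds shows what such a swap does, so the data give no direction for it. The change is expected to stay within the scatter, a number 2.2 percentage points higher from compound 3 to compound 4 (within the scatter). For compound 4 the estimated result in this assay is 22%, between 5% and 45%.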

Compound 4, a percentage reported as inhibition, at one concentration (the size of the read-out at that concentration, not a potency): 19.9%
Beside the measured number, compound 4's estimate is 2.1 percentage points above it; the measured number falls inside the stated range.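

In this assay, going by these compounds alone, there is now a first step between two measured compounds: a number 0.1 percentage points higher from compound 3 to compound 4 (within the scatter) for 2,4-dimethylphenyl in place of 2-methoxyphenyl on an aromatic nitrogen. In this one pair, then, the oxygen of the 2-methoxyphenyl group can be exchanged for carbon-only substitution with a result that stays within the usual scatter. No measured evidence offers an explanation for this result. Going by these compounds, whether a phenyl ring carrying an amine or a carboxylic acid, or a plain longer chain, on that nitrogen would move the number beyond the scatter stays open.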